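This account rests on a few compounds, and the source may have more. Where it says the series, first, only, none or still open, it means among the compounds named here.

Measured compounds:
- compound 1, `CC1=C(C(=O)OCc2ccccc2)C(c2ccc(-c3ccccc3)cc2)N(CCCCCC(=O)O)C(=S)N1`, giving 110000 nM in a toxicity assay on RMS13 cells (Homo sapiens) for inhibition, with a stated time of 24 h; a higher number here means a weaker inhibitor of growth, a lower number a stronger inhibitor of growth
- compound 2, `CC1=C(C(=O)OCc2ccccc2)C(c2ccc(-c3ccccc3C)cc2)NC(=O)N1CCCCCc1nnn[nH]1`, giving 100000 nM in this assay
- compound 3, `CC1=C(C(=O)OCc2ccccc2)C(c2ccc(-c3ccccc3C)cc2)NC(=S)N1Cc1ccc(-c2nnn[nH]2)cc1`, giving 68000 nM in this assay

All three compounds share the same core and act as weak inhibitors of growth in this assay. Going by the values given here, compound 3 carries the lowest of the three numbers, but its gap to compound 2 and its gap to compound 1 both lie within the scatter of repeated measurements, so the three cannot be ordered against one another, and no compound can be called the most or least active on these numbers.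

Compound 4, `CC1=C(C(=O)OCc2ccccc2)C(c2ccc(-c3ccccc3)cc2)NC(=S)N1Cc1ccc(-c2nnn[nH]2)cc1`, has not yet been measured. It differs from compound 3 in one place: hydrogen in place of methyl on an aromatic carbon. Among the compounds with values here, no pair of measured compounds differing in a single place is available, so the size of this step has no direct precedent here. Within the data shown here, the only comparison at hand, compound 1 against compound 3, carries several other changes at once and shows only that both numbers sit within the scatter of each other.

On that basis, compound 4 is expected to remain a weak inhibitor of growth in this assay, with a number close to that of compound 3. The step from compound 3 to compound 4 is estimated as a 1.2-fold higher number from compound 3 to compound 4 (0.07 log units; within the scatter), a change not beyond the scatter. Compound 4 is expected to give 80000 nM, within a range of 35000 nM to 180000 nM.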

Compound 4, concentration for 50% growth inhibition: 87000 nM
Beside the measured number, compound 4's estimate is 1.1-fold (0.04 log units) below it; the range from low to high includes it.
By their numbers in this assay, from the lowest: compounds 3, 4, 2 and 1 (each within the scatter of the next).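

In this assay, going by these compounds alone, the change from 2-methylphenyl to phenyl gives a 1.3-fold higher number from compound 3 to compound 4 (0.11 log units; within the scatter), and this is the first reading of a single change at one place, since the earlier compounds differed from one another in several places at once. It shows that the methyl on this aromatic carbon, ortho to a large group, can be replaced by hydrogen with no difference that stands clear of the scatter, and that both compounds remain weak inhibitors of growth. No accompanying measurement bears on the reason for this result.

Going by these compounds, the step covers only methyl and hydrogen, so it remains open whether a larger or different group at this place, such as a chlorine, a methoxy, an amine or a carboxylic acid, would move the number beyond the scatter. On these data alone, it is also open whether the same change from 2-methylphenyl to phenyl would read alike with the other chains seen in compound 1 and compound 2, or with a longer chain.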